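This account rests on a few compounds, and the source may have more. Where it says the series, first, only, none or still open, it means among the compounds named here.

Measured compounds:
- compound 1, `c1ccc2c(-c3cn4ccnc4c(-c4ccc5ncn(C6CCCCC6)c5c4)n3)cccc2c1`: 4.32%
- compound 2, `O=Cc1ccc(-c2cn3ccnc3c(-c3ccc4ncn(Cc5ccccc5)c4c3)n2)cc1`: 54.5%

In a functional assay on NCI-H23 cells (Homo sapiens) for inhibition, read by sulforhodamine B assay, with a stated time of 48 h, tested at 10 uM (on this read-out higher numbers stand for more inhibition at the one concentration tested (going by the name of the read-out) and lower numbers for less inhibition), compound 2 gives 54.5%, the higher of the two numbers in hand, while in this assay compound 1 gives 4.32%, a gap that lies beyond the usual scatter. Compound 3, `c1ccc(Cn2cnc3ccc(-c4nc(-c5cccc6ccccc56)cn5ccnc45)cc32)cc1`, has not yet been measured in this assay. It differs from compound 2 in one place: naphthalen-1-yl in place of 4-formylphenyl on an aromatic carbon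

Within the data shown here, no single-change step between measured compounds is available, so the expectation for compound 3 rests only on the two values shown. Compound 1 also carries a naphthalen-1-yl group and, in this assay, gives 4.32%, which points to a lower reading once the 4-formylphenyl is gone. In this assay the step of a number 39.5 percentage points lower from compound 2 to compound 3 (beyond the scatter) is expected to be a drop beyond the scatter. Compound 3 is estimated at 15%, with a range from 0% to 40%.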

Compound 3, a percentage reported as inhibition, at one concentration (the size of the read-out at that concentration, not a potency): 10.4%
Beside the measured number, compound 3's estimate is 4.6 percentage points above it, and the stated range covers the measured number.
By their numbers in this assay, from the lowest: compounds 1 and 3 (each within the scatter of the next); then compound 2.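

In this assay, naphthalen-1-yl in place of 4-formylphenyl on an aromatic carbon gives a number 44.1 percentage points lower from compound 2 to compound 3 (beyond the scatter) with the benzyl group held constant, so this position now has a single-change reading, and the outcome there depends strongly on which of these two groups it carries. With naphthalen-1-yl kept in place, benzyl in place of cyclohexyl on an aromatic nitrogen gives a number 6.1 percentage points higher from compound 1 to compound 3 (within the scatter) and so does not separate these two groups in this assay. Nothing given here accounts for the large step at the aromatic carbon.

A single pair cannot show whether the reading of compound 2 follows from the formyl group or from the phenyl ring, and unsubstituted phenyl, 4-aminophenyl or 4-carboxyphenyl at this position would bear on that. From the compounds shown here alone, whether cyclohexyl on the aromatic nitrogen would behave like benzyl alongside 4-formylphenyl also stays open.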